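The source may hold more compounds than are shown below. What is called first, only, known or untested is meant among the compounds shown, and "the series" means these compounds.

Three compounds built on one shared core have been run in a functional assay on the whole organism (strain Swiss) for inhibition, with Mus musculus as the target, in the formalin test, with stated times of 40 min and 30 min, at a dose of 100 umol/kg by the oral route; a lower number here means less inhibition, a higher number more inhibition at the dose given (going by the name of the read-out). Compound 1 `O=C(N/N=C/c1ccc(-c2ccccc2)cc1)c1cnccn1` gives 46.9% in this assay. Compound 2 `COc1ccc(/C=N/NC(=O)c2cnccn2)cc1OC` gives 29.1%, and compound 3 `CC(C)c1ccc(/C=N/NC(=O)c2cnccn2)cc1` gives 66.5%. Among these three numbers compound 1 stands second highest: compound 2 lies below it by more than the scatter, and compound 3 lies above it by more than the scatter.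

Compound 4 `O=C(N/N=C/c1ccc(C(F)(F)F)cc1)c1cnccn1` has not yet been measured. It differs from compound 1 in one place: trifluoromethyl in place of phenyl on an aromatic carbon. For the measured compounds named here, of the measured steps, only one bears on this change, the step of a number 19.6 percentage points higher from compound 1 to compound 3 (beyond the scatter), where a group without a ring likewise took the place of the phenyl on an aromatic carbon. That step was modest and beyond the scatter. Going by the values given here, no measured pair shows a trifluoromethyl itself, so the expectation rests on that single step and is a loose one. The expected step is a number 8.1 percentage points higher from compound 1 to compound 4 (within the scatter), an increase of modest size in this assay, though a result within the scatter of compound 1 would not surprise. Compound 4 is therefore estimated at 55%, with a range from 35% to 75%.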

Compound 4, a percentage reported as inhibition, in the whole organism at one dose (the size of the read-out at that dose, not a potency): 27.7%
Compound 4: the middle estimate sits 27.3 percentage points above what was measured; the measured number lies below the stated range.
By their numbers in this assay, from the lowest: compounds 4 and 2 (each within the scatter of the next); then compound 1; then compound 3.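

In this assay, taking away the phenyl at this position does not move the read-out in one fixed direction: trifluoromethyl in its place gives a number 19.2 percentage points lower from compound 1 to compound 4 (beyond the scatter), the opposite direction to a number 19.6 percentage points higher from compound 1 to compound 3 (beyond the scatter). Both of these replacing groups lack a ring, yet trifluoromethyl in place of isopropyl gives a number 38.8 percentage points lower from compound 3 to compound 4 (beyond the scatter), so the loss of the ring alone does not set the outcome, and the identity of the group that enters matters at this position. Nothing available here accounts for the gap between these groups in the living animal, and no cause can be named.

As far as these compounds go, with only phenyl, isopropyl and trifluoromethyl compared at this position, it remains open where other groups would fall, such as an amine, a carboxylic acid or a longer chain like butyl, and whether any simple trend links the group to the read-out. It also remains open whether the same order of these compounds would hold at other oral doses, since a single dose shows the size of the effect there and not a potency.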